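The source may hold more compounds than are shown below. What is called first, only, known or untested is meant among the compounds shown, and "the series" means these compounds.

Working notes on the amide series. Compound 1 `O=C(Nc1nc(-c2ccccc2)cn2cc(-c3ccccc3)nc12)c1ccc(F)cc1` carries a 4-fluorophenyl group on the carbonyl carbon and gives 38 nM in an assay on cells for displacement of a labelled ligand from transmembrane domain-containing protein TMIGD3 (Homo sapiens), read by scintillation counting, with a stated time of 120 min; a higher number here means a weaker inhibitor, a lower number a stronger inhibitor. Compound 2 `O=C(Nc1nc(-c2ccccc2)cn2cc(-c3ccccc3)nc12)c1ccco1` replaces that group with furan-2-yl; in this assay compound 2 gives 67 nM. Within the data shown here, the only step available, a 1.8-fold higher number from compound 1 to compound 2 (0.25 log units; within the scatter), is within the scatter, so the two measured numbers cannot be ordered against each other. Compound 2 stands at the higher of the two numbers, with compound 1 the nearest neighbour, and nothing beyond the scatter separates them.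

Compound 3 `O=C(Nc1nc(-c2ccccc2)cn2cc(-c3ccccc3)nc12)c1cccs1` is not yet measured. The change from compound 2 is thiophen-2-yl in place of furan-2-yl on a carbonyl carbon. Among the measured compounds shown here, no measured step in this set exchanges one five-membered aromatic ring for another; the one step on this carbonyl carbon, a 1.8-fold higher number from compound 1 to compound 2 (0.25 log units; within the scatter), swapped a six-membered ring for a five-membered one and stayed within the scatter. On that basis no step beyond the scatter is expected in this assay for compound 3, and the estimated step is a 1.3-fold lower number from compound 2 to compound 3 (0.13 log units; within the scatter). For compound 3 the expected value in this assay is 50 nM, with a range from 20 nM to 125 nM.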

Compound 3, inhibition constant: 185 nM
Beside the measured number, compound 3's estimate is 3.7-fold (0.57 log units) below it; measured number outside the range, above it.
By their numbers in this assay, from the lowest: compounds 1 and 2 (each within the scatter of the next); then compound 3.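

On this carbonyl carbon, the earlier step left open whether the ring mattered at all, but the exchange of furan-2-yl for thiophen-2-yl gives a 2.8-fold higher number from compound 2 to compound 3 (0.44 log units; beyond the scatter) in this assay and so passes the scatter, although the two groups match in heavy atoms, in ring size and in hydrogen-bond donors and acceptors, and differ in the oxygen and sulfur of the ring. Measured against 4-fluorophenyl, thiophen-2-yl gives a 4.9-fold higher number from compound 1 to compound 3 (0.69 log units; beyond the scatter) and is again beyond the scatter, which makes compound 3 the weakest of the three, so a five-membered aromatic ring on this carbonyl carbon is not enough to place a compound level with compound 1. Nothing measured here accounts for the difference between the furan-2-yl and thiophen-2-yl amides.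

The compounds shown leave open whether the loss belongs to thiophen-2-yl alone or extends to other rings at this place, such as thiophen-3-yl, thiazol-2-yl or pyridin-2-yl, and how a non-aromatic group such as cyclohexyl or a short alkyl chain would read. They also leave open whether the step from furan-2-yl to thiophen-2-yl would keep its size on a core carrying other groups.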